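Amide tail series: from compound 3 to compound 4

This account rests on a few compounds, and the source may have more. Where it says the series, first, only, none or still open, it means among the compounds named here.

- compound 1 `COc1cc(OC)c(Cl)c(-c2ccc3c(NC(=O)c4ccc(N5CCN(C)CC5)cc4)n[nH]c3n2)c1Cl`: 1.7 nM
- compound 2 `COc1cc(OC)c(Cl)c(-c2ccc3c(NC(=O)c4ccc(N5CCCCC5)cc4)n[nH]c3n2)c1Cl`: 558 nM
- compound 3 `COc1cc(OC)c(Cl)c(-c2ccc3c(NC(=O)c4ccc(C5CCN(C)CC5)cc4)n[nH]c3n2)c1Cl`: 8.2 nM

In a functional assay on NCI-H1581 cells (Homo sapiens) for antiproliferative activity, read by CCK-8 assay, with a stated time of 72 h (on this read-out lower numbers stand for stronger inhibition and higher numbers for weaker inhibition), compound 3 stands second highest of the three numbers at 8.2 nM, with compound 1 lower and compound 2 higher. Compound 4 `CCN1CCN(c2ccc(C(=O)Nc3n[nH]c4nc(-c5c(Cl)c(OC)cc(OC)c5Cl)ccc34)cc2)CC1` carries one change, 4-ethylpiperazin-1-yl in place of 1-methylpiperidin-4-yl on an aromatic carbon.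

Among the compounds with values here, two measured steps bear on this. The modest step of a 4.8-fold higher number from compound 1 to compound 3 (0.68 log units; beyond the scatter) comes with 1-methylpiperidin-4-yl in place of 4-methylpiperazin-1-yl, the closest measured parallel when read in reverse. The large step of a 330-fold higher number from compound 1 to compound 2 (2.52 log units; beyond the scatter), with piperidin-1-yl in place of 4-methylpiperazin-1-yl, shows how far the number can move with this group. Within the data shown here, no measured step covers ethyl in place of methyl on the piperazine, which keeps the range wide.

A modest move to a lower number in this assay is expected, undoing most of a 4.8-fold higher number from compound 1 to compound 3 (0.68 log units; beyond the scatter). The expected step is a 2.7-fold lower number from compound 3 to compound 4 (0.44 log units; beyond the scatter). For compound 4 the estimate is 3 nM, with an expected range of 1 nM to 10 nM.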

Compound 4, half-maximal inhibitory concentration: 0.7 nM
Compound 4: the middle estimate sits 4.3-fold (0.63 log units) above what was measured, outside the stated range (below it).
By their numbers in this assay, from the lowest: compound 4; then compound 1; then compound 3; then compound 2.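

In this assay, the substituent on the piperazine nitrogen proves to matter in its own right: ethyl in place of methyl gives a modest further gain (a 2.4-fold lower number from compound 1 to compound 4 (0.39 log units; beyond the scatter)), so this position accepts the longer group without loss. Compound 4 also sets the ring comparison at a new level, with 4-ethylpiperazin-1-yl well ahead of both 1-methylpiperidin-4-yl (a 12-fold lower number from compound 3 to compound 4 (1.07 log units; beyond the scatter)) and piperidin-1-yl (an 800-fold lower number from compound 2 to compound 4 (2.90 log units; beyond the scatter)), making compound 4 the most potent of the four. No supporting data explain these differences.

On these data alone, whether a propyl, isopropyl or 2-hydroxyethyl group on that nitrogen would extend the gain or reverse it remains open. Also open, as far as these compounds go, is how a morpholin-4-yl ring would compare with the piperazines.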